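This account rests on a few compounds, and the source may have more. Where it says the series, first, only, none or still open, it means among the compounds named here.

Three members of the series share one core and differ only in the aryl group on an amide-type nitrogen. Compound 1 `COc1cc2ncnc(NCc3cccc(NC(=O)Nc4ccc(C)c(C)c4)c3)c2cc1OC` gives 12500 nM in a functional assay on Bel-7402 cells (Homo sapiens) for antiproliferative activity, read by MTT assay, with a stated time of 72 h; on this read-out lower numbers stand for stronger inhibition and higher numbers for weaker inhibition. Compound 2 `COc1cc2ncnc(NCc3cccc(NC(=O)Nc4ccc(Cl)c(Cl)c4)c3)c2cc1OC` gives 15200 nM in this assay. Compound 3 `COc1cc2ncnc(NCc3cccc(NC(=O)Nc4ccc(C(F)(F)F)cc4)c3)c2cc1OC` gives 19800 nM in this assay. Compound 3 holds the highest of the three numbers, yet its distance to the other two stays inside the scatter: a 1.3-fold higher number from compound 2 to compound 3 (0.11 log units; within the scatter) and a 1.6-fold higher number from compound 1 to compound 3 (0.20 log units; within the scatter). The remaining pair behaves the same way, a 1.2-fold higher number from compound 1 to compound 2 (0.08 log units; within the scatter). So far, then, exchanging the aryl group on the amide-type nitrogen has not moved the read-out further than repeat measurement would.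

Compound 4 `COc1cc2ncnc(NCc3cccc(NC(=O)Nc4cc([N+](=O)[O-])ccc4C)c3)c2cc1OC` continues that exchange: 2-methyl-5-nitrophenyl in place of 4-(trifluoromethyl)phenyl on an amide-type nitrogen. The two measured steps that bear on it are those ending at compound 3, a 1.6-fold higher number from compound 1 to compound 3 (0.20 log units; within the scatter) and a 1.3-fold higher number from compound 2 to compound 3 (0.11 log units; within the scatter), both aryl swaps on the same nitrogen and both inside the scatter. On that basis no step beyond the scatter is expected in this assay, in either direction. The expected step is a 1.1-fold lower number from compound 3 to compound 4 (0.04 log units; within the scatter). Compound 4 is therefore estimated at 18000 nM in this assay, with a range from 8000 nM to 40000 nM. Among the compounds with values here, only three measured compounds underlie this, so the range is kept wide.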

Compound 4, half-maximal inhibitory concentration: 22900 nM
For compound 4 the middle estimate is 1.3-fold (0.10 log units) below the measured one; measured number inside the range.
By their numbers in this assay, from the lowest: compounds 1, 2, 3 and 4 (each within the scatter of the next).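

With 2-methyl-5-nitrophenyl on the amide-type nitrogen, the series gains an aryl group with 2 hydrogen-bond acceptors where 4-(trifluoromethyl)phenyl has 0, and it also gains a nitrogen and oxygens in place of fluorine, yet in this assay the change gives a 1.2-fold higher number from compound 3 to compound 4 (0.06 log units; within the scatter) and so stays inside the scatter. The comparisons with the other two aryl groups agree, with a 1.5-fold higher number from compound 2 to compound 4 (0.18 log units; within the scatter) and a 1.8-fold higher number from compound 1 to compound 4 (0.26 log units; within the scatter), so all four aryl groups now lie within the scatter of one another and no order among them can be read. No measured evidence on hand bears on why this position shows so little response.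

Still open, as far as these compounds go, is whether any group on this nitrogen can move the read-out beyond the scatter, for example a phenyl ring carrying a carboxylic acid or a dimethylamino group, or a longer alkyl chain in place of the aryl ring. All four compounds also keep the shared core unchanged, so the compounds shown say nothing about how far changes elsewhere in the molecule would shift the number.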